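The compounds below may be only part of what the source reports. "The series", "measured", "known", "first", "only" and "open" are said of these compounds alone.

Working notes on the series in a functional assay on J774 cells (Mus musculus) for cytotoxicity, read by resazurin assay, with a stated time of 72 h (a lower number here means a stronger inhibitor, a higher number a weaker inhibitor), follow. Compound 1 `O=S(=O)(Nc1cccc(CO)c1)c1ccc(-c2ccccc2)cc1` gives 2200 nM and sits within the scatter of compound 3 `O=S(=O)(Nc1cc(CO)cc(CO)c1)c1ccc(-c2ccc(Cl)cc2Cl)cc1` with 2500 nM at the upper end of this small set. Compound 2 `O=S(=O)(Nc1cc(CO)ccc1O)c1ccc(-c2ccc(Br)cc2)cc1` gives 1000 nM as a lower number than compound 1, beyond the scatter. Compound 4 `O=S(=O)(Nc1cccc(CO)c1)c1ccc(-c2ccc3cc[nH]c3c2)cc1` carries 1H-indol-6-yl in place of phenyl on an aromatic carbon, para to a large group. The change from compound 1 is 1H-indol-6-yl in place of phenyl on an aromatic carbon and the rest of the core stays the same. Among the compounds with values here, no measured pair shows a swap of this kind, so no step beyond the scatter is expected in this assay and any drift is expected toward a lower number. The expected move is a 1.2-fold lower number from compound 1 to compound 4 (0.09 log units; within the scatter) and no more. The estimate for compound 4 is 1800 nM with 800 nM to 4000 nM as its expected range.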

Compound 4, half-maximal inhibitory concentration: 2500 nM
Estimate against measurement, compound 4: 1.4-fold (0.14 log units) below; the range from low to high includes it.
By their numbers in this assay, from the lowest: compound 2; then compounds 1, 3 and 4 (each within the scatter of the next).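

In this assay the step is a 1.1-fold higher number from compound 1 to compound 4 (0.06 log units; within the scatter), with 1H-indol-6-yl in place of phenyl on an aromatic carbon, para to a large group. Within the data shown here, this is the first step that changes one place only, and it shows that this position takes the added five-membered aromatic ring and hydrogen-bond donor with no step beyond the scatter. No measured evidence bears on this result. Going by these compounds, whether an amine or a carboxylic acid at this position would give a step beyond the scatter stays open.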